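Cytotoxicity of Ether Variants on a Shared Core

The compounds below may be only part of what the source reports. "The series", "measured", "known", "first", "only" and "open" are said of these compounds alone.

Compound 1 `CCC1(Cc2ccccc2)OS(=O)(=O)C=C1OCc1ccc(OC)cc1`: >= 200000 nM
Compound 2 `CCC1(Cc2ccccc2)OS(=O)(=O)C=C1OCc1ccc(Cl)cc1`: >= 50000 nM
Compound 3 `CCC1(Cc2ccccc2)OS(=O)(=O)C=C1OCc1ccc(Br)cc1`: 80000 nM

In an ADME assay on HEL cells (Homo sapiens) for cytotoxicity, with a stated time of 3 days (a higher number here means that more compound is tolerated, a lower number that less compound is tolerated), compound 1 reaches only a limit, >= 200000 nM. Compound 2 likewise reaches a limit, >= 50000 nM. For the measured compounds named here, compound 3 gives the only actual number, 80000 nM, and the one readable step, an at least 2.5-fold lower number from compound 1 to compound 3 (0.39 log units; beyond the scatter), shows that changing the group on this part of the core can move the number modestly. Compound 4 `C=CCOC1=CS(=O)(=O)OC1(CC)Cc1ccccc1` differs from compound 3 by vinyl in place of 4-bromophenyl on a saturated chain carbon bound to an oxygen on an unsaturated carbon. Going by the values given here, no measured step removes the aromatic ring here, so the direction is open; the steps seen so far are modest or unreadable. Compound 4 is expected to give about 100000 nM, between 40000 nM and 250000 nM. This estimate means a step of a 1.3-fold higher number from compound 3 to compound 4 (0.10 log units; within the scatter), within the scatter.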

Compound 4, minimum cytotoxic concentration: 80000 nM
For compound 4 the middle estimate is 1.3-fold (0.10 log units) above the measured one; the range from low to high includes it.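

In this assay, putting vinyl in place of 4-bromophenyl removes the aromatic ring and gives no change at the digits printed from compound 3 to compound 4 (within the scatter), so at this place an aromatic ring is not required to hold this number. Without that ring, the allyl compound also shows an at least 2.5-fold lower number from compound 1 to compound 4 (0.39 log units; beyond the scatter). Compound 1 stands at a limit, >= 200000 nM, so that step gives a bound only.

On these data alone, the step involving compound 2 cannot be read, because that compound stands at a limit: the limit of >= 50000 nM in this assay, at which 1 of the 4 values shown sits. Whether an amine or a longer chain at this place would leave the number unchanged stays open.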